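Compound 4: Dropping the Ethyl Group from the Shared Core

The source may report more compounds than this note shows. Statements on the series, on what has been measured and on what is new or still open speak of the compounds shown alone.

Compound 1 `CC[C@H]1c2cc(Cl)ccc2C(=O)N1c1cncc2c1CCC[C@H]2NC(C)=O` gives 97 nM in an assay on cells for inhibition of cytochrome P450 11B2, mitochondrial (Homo sapiens), read by HTRF; a higher number here means a weaker inhibitor, a lower number a stronger inhibitor.
Compound 2 `CCC(=O)N[C@@H]1CCCc2c1cncc2N1C(=O)c2ccc(Cl)cc2[C@@H]1CC` gives 12 nM in this assay.
Compound 3 `CCS(=O)(=O)N1CC2(CN(c3cncc(N4C(=O)c5ccc(Cl)cc5C4(C)C)c3)C2)C1` gives 16 nM in this assay.

Compound 1 stands highest of the three numbers in this assay: compound 3 lies nearest to it and compound 2 furthest, and both gaps lie beyond the scatter. Compound 4 `CC(=O)N[C@@H]1CCCc2c1cncc2N1Cc2cc(Cl)ccc2C1=O` differs from compound 1 in one place: hydrogen in place of ethyl on a saturated ring carbon.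

For the measured compounds named here, the only measured step, an 8.1-fold lower number from compound 1 to compound 2 (0.91 log units; beyond the scatter), concerns a change at a different place, on the chain bound to the carbonyl carbon, and so bears only loosely on the question. Going by the values given here, no measured compound lacks a group on the saturated ring carbon that carries the ethyl in compound 1; compound 3 carries two methyl groups there, while also differing elsewhere, so its value shows nothing separable about that carbon. Compound 4 is therefore expected, with low confidence, to move toward a higher number, the step estimated at a 2.6-fold higher number from compound 1 to compound 4 (0.41 log units; beyond the scatter). Compound 4 is estimated at 250 nM, within a range of 90 nM to 800 nM.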

Compound 4, half-maximal inhibitory concentration: 44 nM
Beside the measured number, compound 4's estimate is 5.7-fold (0.75 log units) above it, outside the stated range (below it).
By their numbers in this assay, from the lowest: compounds 2 and 3 (each within the scatter of the next); then compound 4; then compound 1.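

In this assay, for the compounds shown here, a 2.2-fold lower number from compound 1 to compound 4 (0.34 log units; beyond the scatter) is the first measured step at this saturated ring carbon, next to the ring nitrogen, and it shows that the ethyl group is not needed for a lower number on this core. Loss of the ethyl group, with its 2 carbon atoms, improves inhibition modestly rather than weakening it, so a group at this carbon is no requirement for inhibition in this pair. No measurement shown here accounts for why the number falls with this change.

From the compounds shown here alone, it remains open whether the same replacement of ethyl by hydrogen would lower the number on the propanoyl amide of compound 2. Going by these compounds, it is also open how a single methyl group or a longer chain such as propyl at this carbon would compare with hydrogen and ethyl.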